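Carbamoyl to methylsulfonyl on the lysine-derived side chain

The source may report more compounds than this note shows. Statements on the series, on what has been measured and on what is new or still open speak of the compounds shown alone.

Measured compounds:
compound 1 `COC(=O)[C@H](CCCCNC(N)=O)N(C/C=C/c1cccc(Oc2ccccc2)c1)C/C=C/c1cccc(Oc2ccccc2)c1`, 35000 nM
compound 2 `COC(=O)[C@H](CCCCN)N(/C=C/Cc1cccc(Oc2ccccc2)c1)Cc1cccc(Oc2ccccc2)c1`, 30000 nM
compound 3 `COC(=O)[C@H](CCCCN)N(/C=C/Cc1cccc(Oc2ccc(C(C)(C)C)cc2)c1)Cc1cccc(OCc2ccccc2)c1`, 10000 nM

All three were tested in an assay on isolated protein for binding affinity to erythropoietin receptor (Homo sapiens); a higher number here means a weaker inhibitor, a lower number a stronger inhibitor. Compound 1 sits at the top end of these three numbers: compound 2 lies within the scatter of it, while compound 3 is beyond the scatter, the only gap here that counts as a difference. Compound 4 `COC(=O)[C@H](CCCCNS(C)(=O)=O)N(C/C=C/c1cccc(Oc2ccccc2)c1)C/C=C/c1cccc(Oc2ccccc2)c1` is not yet measured. It differs from compound 1 in one place: methylsulfonyl in place of carbamoyl on an amine nitrogen. For the measured compounds named here, no measured pair shows this change, so its effect is unknown. With nothing to point either way, no step beyond the scatter is expected; the estimate for compound 4 in this assay is 30000 nM, spanning 10000 nM to 90000 nM, which means an expected step of a 1.2-fold lower number from compound 1 to compound 4 (0.07 log units; within the scatter) of no consequence.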

Compound 4, half-maximal inhibitory concentration: 35000 nM
Estimate against measurement, compound 4: 1.2-fold (0.07 log units) below; the measured number falls inside the stated range.
By their numbers in this assay, from the lowest: compound 3; then compounds 2, 1 and 4 (each within the scatter of the next).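

In this assay, methylsulfonyl in place of carbamoyl on an amine nitrogen gives no change at the digits printed from compound 1 to compound 4 (within the scatter). For the compounds shown here, this is the first one-place comparison: on the core of compound 1, a group with no hydrogen-bond donor replaces one that has a hydrogen-bond donor, with no readable shift. Nothing measured here bears on why the number holds.

Still open, as far as these compounds go, is whether any group at this position moves the number on this core. A free amine, an acetyl group or a carboxylic acid on a longer chain would test that.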